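Adding a methyl to the phenyl ring of compound 3

The compounds below may be only part of what the source reports. "The series", "measured", "known", "first", "only" and "open" are said of these compounds alone.

The measurements here come from a functional assay on HL-60 cells (Homo sapiens) for cytotoxicity, read by MTT assay, with a stated time of 4 days; a lower number here means a stronger inhibitor, a higher number a weaker inhibitor. Within the data shown here, compound 1, with the structure `COc1ccc(-c2cn(C[C@H]3c4c(ccc(OS(=O)(=O)c5ccc(C)cc5)c4C)[C@@H]4CC[C@@]5(C)C[C@]43CC5=O)nn2)cc1`, is one of three compounds measured so far. In this assay compound 1 gives > 20000 nM, which is a limit of the assay and not a number. Compound 2, `C=C1C[C@]23C[C@@]1(O)CC[C@H]2c1ccc(O)c(C)c1[C@@H]3Cn1cc(-c2ccccc2)nn1`, is a smaller relative. In this assay compound 2 likewise gives only the limit > 20000 nM. Compound 3, `C=C1C[C@]23C[C@@]1(O)CC[C@H]2c1cc(Br)c(O)c(C)c1[C@@H]3Cn1cc(-c2ccccc2)nn1`, carries a bromo in place of hydrogen on an aromatic carbon relative to compound 2. In this assay compound 3 again gives only the limit > 20000 nM. The step that the two limits leave unreadable from compound 2 to compound 3 therefore cannot be read, and compound 3 stands where all three values stand: at the limit of > 20000 nM in this assay, at which 3 of the 3 values shown sit.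

Compound 4, `C=C1C[C@]23C[C@@]1(O)CC[C@H]2c1cc(Br)c(O)c(C)c1[C@@H]3Cn1cc(-c2ccc(C)cc2)nn1`, differs from compound 3 by methyl in place of hydrogen on an aromatic carbon. Among the measured compounds shown here, the only measured step that touches this series, the one from compound 2 to compound 3, gives no readable size, so there is no measured guide for a methyl in this position. Given that every value so far is a limit, compound 4 is expected to show a step of a number no higher from compound 3 to compound 4 (the limit leaves the size open), that is, none beyond the scatter. The estimate for compound 4 is 20000 nM, with a range from 8000 nM to 60000 nM.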

Compound 4, half-maximal inhibitory concentration: > 20000 nM
Compound 4 gave a limit, no number; the forecaster's own chance of this, stated with the estimate: 80%; the middle value sits exactly at the limit.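

Among these compounds, compound 3 and compound 4 both give a limit of the assay and not a number, so no step between them can be read in this assay. The compounds shown leave open what size of effect, if any, the bromo or the methyl has, since every value stands at the same place: the limit of > 20000 nM in this assay, at which 4 of the 4 values shown sit.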